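Methoxy in Place of Fluoro on the Aryl Ring

The source may hold more compounds than are shown below. What is called first, only, known or untested is meant among the compounds shown, and "the series" means these compounds.

Compound 1 `O=C(/C=C\Nc1ccc(F)cc1)c1cn(-c2ccccc2)nc1-c1ccc(F)cc1`: 7900 nM
Compound 2 `O=C(/C=C\Nc1ccc(Cl)cc1)c1cn(-c2ccccc2)nc1-c1ccc(F)cc1`: 3800 nM

Both compounds were tested in a functional assay on PC-3 cells (Homo sapiens) for antiproliferative activity, read by MTT assay, with a stated time of 48 h; a higher number here means a weaker inhibitor, a lower number a stronger inhibitor. Compound 1 gives the highest of the two numbers; its nearest neighbour is compound 2, and the move there is a 2.1-fold lower number from compound 1 to compound 2 (0.32 log units; beyond the scatter), a modest step that comes from chloro in place of fluoro on an aromatic carbon. Compound 3 `COc1ccc(-c2nn(-c3ccccc3)cc2C(=O)/C=C\Nc2ccc(F)cc2)cc1` has not yet been measured. For the measured compounds named here, it differs from compound 1 by methoxy in place of fluoro on an aromatic carbon, a change on a different aromatic ring from the one altered between compound 1 and compound 2, so the single measured step does not touch the same place. Going by the values given here, that step is the only guide available, and it shows that swapping one halogen for another elsewhere on compound 1 shifts the number only modestly. Among the compounds with values here, with no example of a methoxy anywhere in the set, the account expects no step beyond the scatter, with at most a small lean toward a lower number: a 1.1-fold lower number from compound 1 to compound 3 (0.05 log units; within the scatter). Compound 3 is therefore estimated at 7000 nM, within a range from 2500 nM to 20000 nM.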

Compound 3, half-maximal inhibitory concentration: 5730 nM
Compound 3: middle estimate off by 1.2-fold (0.09 log units), on the high side; the measured number falls inside the stated range.
By their numbers in this assay, from the lowest: compounds 2, 3 and 1 (each within the scatter of the next, the first and the last beyond it).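

In this assay, the exchange of 4-fluorophenyl for 4-methoxyphenyl gives a 1.4-fold lower number from compound 1 to compound 3 (0.14 log units; within the scatter), so this aromatic ring, which the earlier pair left unchanged, takes a methoxy in place of the fluoro without a step beyond the scatter. The earlier compounds had shown only one halogen exchanged for another on a different aromatic ring, whereas here the entering group is not a halogen: two heavy atoms and one hydrogen-bond acceptor stand where a single fluorine stood, and the number still stays within the scatter of that of the parent. Nothing measured here bears on what lies behind this result.

As far as these compounds go, whether this tolerance extends to other groups at the same place remains open, since one substituent cannot show how far it reaches; an amine, a carboxylic acid or a longer chain such as butoxy could each give a different answer. From the compounds shown here alone, it also remains open whether the methoxy on this ring and the chloro on the other ring would add up when carried together on the shared core.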